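Urea to amide on the pyrazole series: anilide variant

The source may report more compounds than this note shows. Statements on the series, on what has been measured and on what is new or still open speak of the compounds shown alone.

Measured so far:
compound 1 `COc1cc(Cl)cc(-c2nn(-c3cccc(NC(=O)Nc4ccc(Cl)c(C(F)(F)F)c4)c3)cc2-c2ccncc2)c1` — -62%
compound 2 `COc1cc(Cl)cc(-c2nn(-c3cccc(NC(=O)Nc4cc(C(F)(F)F)cc(C(F)(F)F)c4)c3)cc2-c2ccncc2)c1` — -84%

In a functional assay on NCI-H460 cells (Homo sapiens) for inhibition, read by sulforhodamine B assay, with a stated time of 48 h, tested at 100 uM (a lower number here means a stronger effect, a higher number a weaker effect of the compound at the concentration tested), compound 1 gives -62%. Compound 1 stands highest of the two numbers; compound 2 gives -84%, a value that lies beyond the scatter below it. Among the measured compounds shown here, no step between measured pairs differing in one place is available.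

Compound 3 `COc1cc(Cl)cc(-c2nn(-c3cccc(NC(=O)c4cccc(C(F)(F)F)c4)c3)cc2-c2ccncc2)c1` is the next candidate. Against compound 1 the change is 3-(trifluoromethyl)phenyl in place of (4-chloro-3-(trifluoromethyl)phenyl)amino on a carbonyl carbon. Without any measured step of this kind, the expectation rests on the two values alone. The step from compound 1 to compound 3 is expected to raise the number, a number 37 percentage points higher from compound 1 to compound 3 (beyond the scatter), a weaker effect. Compound 3 is estimated at -25%, with a range from -55% to 10%.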

Compound 3, a percentage reported as activity, at one concentration (the size of the read-out at that concentration, not a potency): 30%
The estimate for compound 3 lay 55 percentage points below the measured number; measured number above the stated range.
By their numbers in this assay, from the lowest: compound 2; then compound 1; then compound 3.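

In this assay, replacing (4-chloro-3-(trifluoromethyl)phenyl)amino with 3-(trifluoromethyl)phenyl on the carbonyl carbon gives a number 92 percentage points higher from compound 1 to compound 3 (beyond the scatter). The sign of the read-out changes as well: compound 3 gives 30%, whereas compound 1 gives -62%, so this position strongly affects the read-out. This single step removes both the amino nitrogen and the chlorine, and no available evidence explains its size.

On these data alone, the separate contributions of the amino nitrogen and the chlorine remain open. Also open, as far as these compounds go, is how a methylene linker on the carbonyl carbon would compare.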